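Methyl to Fluoro on the Sulfonyl Aryl Ring

The source may hold more compounds than are shown below. What is called first, only, known or untested is meant among the compounds shown, and "the series" means these compounds.

In an ADME assay on microsomes from liver (Homo sapiens) for metabolic stability, tested at 2.5 uM (on this read-out higher numbers stand for fast clearance and lower numbers for slow clearance), compound 2 `Cc1ccc(S(=O)(=O)c2cnc3cc(F)ccc3c2-c2cccc(F)c2)cc1F` gives 0.41 mL/min. Compound 1 `O=S(=O)(c1ccc(F)c(F)c1)c1cnc2cc(F)ccc2c1-c1cccc(Cl)c1` gives 0.38 mL/min in this assay, and the two numbers sit within the usual scatter of each other, so neither can be set apart from the other on these data. Compound 3 `O=S(=O)(c1ccc(F)c(F)c1)c1cnc2cc(F)ccc2c1-c1cccc(F)c1` has not yet been measured. It differs from compound 2 in one place: fluoro in place of methyl on an aromatic carbon. No step between measured compounds mirrors this change, so the expectation rests on the two numbers shown. Given that compound 1 gives 0.38 mL/min and compound 2 gives 0.41 mL/min in this assay, the step from compound 2 to compound 3 is expected to be small, as a 1.1-fold lower number from compound 2 to compound 3 (0.03 log units; within the scatter), not beyond the scatter in either direction. Compound 3 is therefore estimated to give about 0.38 mL/min in this assay, within a range from 0.24 mL/min to 0.6 mL/min.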

Compound 3, intrinsic clearance in a liver preparation (reported as CLH), per the amount of preparation that the assay uses: 0.6 mL/min
Estimate against measurement, compound 3: 1.6-fold (0.20 log units) below, within the range that was stated.
By their numbers in this assay, from the lowest: compounds 1, 2 and 3 (each within the scatter of the next).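

In this assay, fluoro in place of methyl, which turns the 3-fluoro-4-methylphenyl group into the 3,4-difluorophenyl group, gives a 1.5-fold higher number from compound 2 to compound 3 (0.17 log units; within the scatter), so on this core the exchange at this position is not told apart from the scatter. Fluoro in place of chloro on an aromatic carbon gives a 1.6-fold higher number from compound 1 to compound 3 (0.20 log units; within the scatter), so this exchange also stays within the scatter, and compound 3 now joins both earlier compounds through changes in one place. No measurement shown here offers an explanation for these numbers.

From the compounds shown here alone, how a larger change at the same carbon would read stays open, for instance an amine, a methoxy group or a carboxylic acid. Going by these compounds, the methyl to fluoro exchange is also seen on one background only, so whether it reads the same with other groups elsewhere on the core is unknown.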